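Aryl swap on the ring nitrogen: compound 3 to compound 4

This account rests on a few compounds, and the source may have more. Where it says the series, first, only, none or still open, it means among the compounds named here.

Measured compounds:
compound 1 `N#CC1=C(N)Oc2c(N)cc3nc4ccccc4nc3c2C12C(=O)N(Cc1cnnn1-c1ccc(F)cc1)c1ccccc12` — > 50000 nM
compound 2 `COc1ccc(-n2nncc2CN2C(=O)C3(C(C#N)=C(N)Oc4c(N)cc5nc6ccccc6nc5c43)c3ccccc32)cc1` — > 50000 nM
compound 3 `CCc1cccc(C)c1-n1nncc1CN1C(=O)C2(C(C#N)=C(N)Oc3c(N)cc4nc5ccccc5nc4c32)c2ccccc21` — > 50000 nM

In a functional assay on MCF7 cells (Homo sapiens) for antiproliferative activity, read by MTT assay, with a stated time of 48 h (a higher number here means a weaker inhibitor, a lower number a stronger inhibitor), compound 1 gives > 50000 nM, which is a limit of the assay and not a number. Compound 2 likewise gives only a limit, > 50000 nM. Compound 3 also gives only a limit, > 50000 nM. Compound 3 therefore stands at the limit of > 50000 nM in this assay, at which 3 of the 3 values shown sit, together with the other two, and the steps a step that the two limits leave unreadable from compound 1 to compound 2, a step that the two limits leave unreadable from compound 1 to compound 3 and a step that the two limits leave unreadable from compound 2 to compound 3 cannot be sized.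

Compound 4 `N#CC1=C(N)Oc2c(N)cc3nc4ccccc4nc3c2C12C(=O)N(Cc1cnnn1-c1ccc(F)c(Cl)c1)c1ccccc12` differs from compound 3 by 3-chloro-4-fluorophenyl in place of 2-ethyl-6-methylphenyl on an aromatic nitrogen. No measured step reads on this change; all three shown steps are unreadable. Compound 4 is therefore expected to sit at the same limit, estimated at 60000 nM (range 15000 nM to 250000 nM), an expected step that the limit leaves unreadable from compound 3 to compound 4.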

Compound 4, half-maximal inhibitory concentration: 17800 nM
For compound 4 the middle estimate is 3.4-fold (0.53 log units) above the measured one, within the range that was stated.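

In this assay this position on the aromatic nitrogen gives its first readable result: chloro in place of hydrogen on an aromatic carbon is enough for an at least 2.8-fold lower number from compound 1 to compound 4 (0.44 log units; beyond the scatter). The wider aryl swaps give an at least 2.8-fold lower number from compound 2 to compound 4 (0.44 log units; beyond the scatter) and an at least 2.8-fold lower number from compound 3 to compound 4 (0.44 log units; beyond the scatter), so among the groups shown only 3-chloro-4-fluorophenyl leaves the limit. The steps among compound 1, compound 2 and compound 3 cannot be read, as all three sit at a limit: the limit of > 50000 nM in this assay, at which 3 of the 4 values shown sit.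

On these data alone, the true size of the three new steps stays open. Also open, as far as these compounds go, is whether 3-chlorophenyl alone carries the gain, and how an aminophenyl or carboxyphenyl group would read here.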